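The compounds below may be only part of what the source reports. "The series", "measured", "known", "first", "only" and "open" are said of these compounds alone.

Measured compounds in a functional assay on HeLa cells (Homo sapiens) for cytotoxicity, read by MTT assay, with a stated time of 72 h; on this read-out lower numbers stand for stronger inhibition and higher numbers for weaker inhibition:
compound 1 `FC(F)(F)c1cc(/N=N/Nc2ccc(Cl)c(C(F)(F)F)c2)ccc1Cl` gives 58400 nM
compound 2 `CC(=O)N(/N=N/c1ccc(Cl)c(C(F)(F)F)c1)c1ccc(Cl)c(C(F)(F)F)c1` gives 50600 nM
compound 3 `O=[N+]([O-])c1ccc(/N=N/Nc2ccc([N+](=O)[O-])cc2Br)c(Br)c1` gives 940 nM

Compound 3 stands lowest of the three numbers in this assay; the nearest is compound 2, and the gap to it, as to compound 1, lies beyond the scatter. Compound 4 `O=C(c1ccccc1F)N(/N=N/c1ccc([N+](=O)[O-])cc1Br)c1ccc([N+](=O)[O-])cc1Br` is not yet measured. It differs from compound 3 in one place: (2-fluorophenyl)carbonyl in place of hydrogen on a nitrogen on an aromatic ring.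

Within the data shown here, the only measured step on the same nitrogen is the one in which an acetyl replaces the hydrogen, a 1.2-fold lower number from compound 1 to compound 2 (0.06 log units; within the scatter). That step lies within the scatter, so acylation at this position has so far left this assay essentially unchanged. Among the measured compounds shown here, the group entering compound 4 is larger than acetyl, and no step with a six-membered aromatic ring on that nitrogen is on record, so the expectation rests on a single small step and carries a wide range. The step from compound 3 to compound 4 is therefore expected to be small, a 1.3-fold higher number from compound 3 to compound 4 (0.11 log units; within the scatter), in no clear direction beyond the scatter. For compound 4 the estimate in this assay is 1200 nM, with a range from 400 nM to 4000 nM.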

Compound 4, half-maximal inhibitory concentration: 1200 nM
Compound 4: middle estimate and measured number agree at the digits printed, and the stated range covers the measured number.
By their numbers in this assay, from the lowest: compounds 3 and 4 (each within the scatter of the next); then compounds 2 and 1 (each within the scatter of the next).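

In this assay, a 1.3-fold higher number from compound 3 to compound 4 (0.11 log units; within the scatter), so the (2-fluorophenyl)carbonyl group, with its 9 heavy atoms and six-membered aromatic ring, leaves the number within the scatter at a place previously probed only with acetyl. Read with a 1.2-fold lower number from compound 1 to compound 2 (0.06 log units; within the scatter), this gives two acylations of this nitrogen within the scatter, on two different cores, and neither listed step goes against that pattern. Nothing measured here bears on why the number stays within the scatter after either acylation.

On these data alone, it remains open whether a non-acyl group on this nitrogen, such as methyl or a longer alkyl chain, would also stay within the scatter, and whether an acyl group carrying an amine or a carboxylic acid would do so. As far as these compounds go, the part played by the fluorine is also open, and a plain benzoyl group on the same nitrogen would test it.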